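Alkyl group on the imine nitrogen of the shared core

A few compounds are considered here, and "the series" means these few. Any claim that something is new, unique, unknown or untested is made for them only; others in the source may bear on it.

Compound 1, `CCC(CC)/N=c1\c(O)c(O)\c1=N/Cc1ccc(C#N)cc1`: 1300 nM
Compound 2, `CCc1cc(C#N)ccc1C/N=c1\c(O)c(O)\c1=N/[C@H](C)C(C)(C)C`: 2000 nM

Both compounds were measured in a functional assay for inhibition, with Rattus norvegicus as the target; a higher number here means a weaker inhibitor, a lower number a stronger inhibitor. Compound 1 gives 1300 nM in this assay and compound 2 gives 2000 nM. Compound 1 has the lower of the two numbers, but the gap to compound 2 lies within the scatter, so no order between them can be read; compound 2 also differs from compound 1 in more than one place, so nothing about a single change follows from the pair.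

Compound 3, `CC[C@@H](C)/N=c1\c(O)c(O)\c1=N/Cc1ccc(C#N)cc1`, differs from compound 1 in one place: sec-butyl in place of pentan-3-yl on a double-bonded nitrogen. For the measured compounds named here, no step between measured compounds differing in one place is available, so this change has no direct precedent. The step is expected to be small, a 1.4-fold higher number from compound 1 to compound 3 (0.14 log units; within the scatter), with no direction beyond the scatter. Compound 3 is estimated at 1800 nM in this assay, within 900 nM to 3600 nM.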

Compound 3, half-maximal inhibitory concentration: 4000 nM
Compound 3: middle estimate off by 2.2-fold (0.35 log units), on the low side, and the stated range ends below it.
By their numbers in this assay, from the lowest: compounds 1, 2 and 3 (each within the scatter of the next, the first and the last beyond it).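

Pentan-3-yl to sec-butyl on a double-bonded nitrogen gives the first one-place comparison in the series: in this assay there is a 3.1-fold higher number from compound 1 to compound 3 (0.49 log units; beyond the scatter), a modest step towards weaker inhibition. The earlier pair could not show this, but the position is now seen to respond to the alkyl group, with a change from 5 carbon to 4 and a new defined stereocentre together moving the number beyond the scatter. Nothing at hand gives a measured basis for the step, so it stands as an observation only.

Still open, as far as these compounds go, is whether the carbon count or the stereocentre carries the step, which the opposite sec-butyl configuration could help to separate. From the compounds shown here alone, it is also open how far the trend extends, and a cyclopentyl group or a longer chain such as heptan-4-yl on the same nitrogen would test whether the number drops further.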